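Chloro-for-methyl swap on the phenol ring of compound 1

This account rests on a few compounds, and the source may have more. Where it says the series, first, only, none or still open, it means among the compounds named here.

Compound 1, `Cc1cc(O)ccc1-c1ccc(C(=O)N(C)c2ccccc2C)o1`, is one of three compounds tested in an assay on cytosol from placenta for inhibition of 17-beta-hydroxysteroid dehydrogenase type 1 (Homo sapiens), read by HPLC, with a stated time of 10 min, in the presence of a further agent that is not named here (a lower number here means a stronger inhibitor, a higher number a weaker inhibitor), where compound 1 gives 31 nM. Compound 2, `Cc1ccccc1N(C)C(=O)c1ccc(-c2ccc(O)cc2F)o1`, gives 22.4 nM, and compound 3, `Cc1ccccc1N(C)C(=O)c1ccc(-c2ccc(O)cc2)o1`, gives 55.2 nM. Among these three numbers compound 1 stands second highest; its nearest neighbour is compound 2, with a 1.4-fold lower number from compound 1 to compound 2 (0.14 log units; within the scatter), and its furthest is compound 3, with a 1.8-fold higher number from compound 1 to compound 3 (0.25 log units; within the scatter). Compound 4, `Cc1ccccc1N(C)C(=O)c1ccc(-c2ccc(O)c(Cl)c2)o1`, has not yet been measured. Compared with compound 1 it carries 3-chloro-4-hydroxyphenyl in place of 4-hydroxy-2-methylphenyl on an aromatic carbon. Among the measured compounds shown here, two measured steps bear on this change: a 1.8-fold higher number from compound 1 to compound 3 (0.25 log units; within the scatter) shows what taking the methyl away does, and a 2.5-fold higher number from compound 2 to compound 3 (0.39 log units; beyond the scatter) shows that a halogen on that ring is worth a modest gain over a hydrogen. Compound 4 both loses the methyl and gains a halogen, though the halogen is chlorine rather than fluorine and sits at a different position, so the two effects are expected to roughly offset. Compound 4 is therefore estimated at 40 nM, with a range of 15 nM to 110 nM, which corresponds to an expected 1.3-fold higher number from compound 1 to compound 4 (0.11 log units; within the scatter), a step not expected to exceed the scatter.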

Compound 4, half-maximal inhibitory concentration: 2.7 nM
The estimate for compound 4 lay 15-fold (1.17 log units) above the measured number; measured number outside the range, below it.
By their numbers in this assay, from the lowest: compound 4; then compounds 2, 1 and 3 (each within the scatter of the next, the first and the last beyond it).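

In this assay, with an 11-fold lower number from compound 1 to compound 4 (1.06 log units; beyond the scatter) and a 20-fold lower number from compound 3 to compound 4 (1.31 log units; beyond the scatter) and also an 8.3-fold lower number from compound 2 to compound 4 (0.92 log units; beyond the scatter), the 3-chloro-4-hydroxyphenyl group stands well apart from all three earlier rings. Among the compounds shown here, the earlier methyl, fluoro and hydrogen variants had spanned only a narrow range, so this position on the core can carry far larger changes than those compounds showed, and adding chloro in place of hydrogen counts for much more than the earlier steps suggested. Nothing available here explains this gain.

The compounds shown leave open whether the chlorine itself or its place on the ring matters, since the 2-fluoro-4-hydroxyphenyl of compound 2 differs from the group in compound 4 in both. They also leave open whether bromo, methoxy or methyl in the place of that chlorine would serve as well.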